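The compounds below may be only part of what the source reports. "The series", "measured", "known", "first", "only" and "open" are said of these compounds alone.

Compound 1 `COc1cc[nH]c1/C=C1\C(=O)Nc2ccc(F)c(C#CC(O)CN)c21`: 130 nM
Compound 2 `CCN[C@H](C#Cc1c(F)ccc2c1/C(=C/c1[nH]ccc1OC)C(=O)N2)[C@@H](C)O`: 1070 nM
Compound 3 `COc1cc[nH]c1/C=C1\C(=O)Nc2ccc(F)c(C#CC3(O)CCOCC3)c21`: 600 nM

In a functional assay on MDA-MB-435 cells (Homo sapiens) for inhibition (a lower number here means a stronger inhibitor, a higher number a weaker inhibitor), compound 1 gives the lowest number of the three measured compounds; compound 3 comes nearest to it and compound 2 lies furthest away, both beyond the scatter. The step to compound 4 `COc1cc[nH]c1/C=C1\C(=O)Nc2ccc(F)c(C#C[C@@H]3C[C@@H](O)CN3)c21` changes the same part of the molecule as the two measured steps: 4-hydroxypyrrolidin-2-yl in place of 2-amino-1-hydroxyethyl on a triple-bonded carbon. The measured steps that bear on it are an 8.2-fold higher number from compound 1 to compound 2 (0.92 log units; beyond the scatter) and a 4.6-fold higher number from compound 1 to compound 3 (0.66 log units; beyond the scatter). In both, replacing the 2-amino-1-hydroxyethyl group on the triple-bonded carbon gave a higher number, beyond the scatter, and of modest size. Compound 4 replaces that group with a five-membered ring that still carries a hydroxyl and a nitrogen, so a modest rise in the number is expected rather than a fall. Compound 4 is therefore expected to give about 400 nM, with a likely range from 150 nM to 1100 nM. The expected step is a 3.1-fold higher number from compound 1 to compound 4 (0.49 log units; beyond the scatter).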

Compound 4, half-maximal inhibitory concentration: 63 nM
Estimate against measurement, compound 4: 6.3-fold (0.80 log units) above; the whole stated range lies above it.
By their numbers in this assay, from the lowest: compound 4; then compound 1; then compounds 3 and 2 (each within the scatter of the next).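

In this assay, the two earlier replacements of the 2-amino-1-hydroxyethyl group on the triple-bonded carbon both raised the number, but the 4-hydroxypyrrolidin-2-yl group gives a 2.1-fold lower number from compound 1 to compound 4 (0.31 log units; beyond the scatter) and so shows that this position can take a larger group, here a ring, and the number can still fall. The other replacements compare poorly, with a 9.5-fold lower number from compound 3 to compound 4 (0.98 log units; beyond the scatter) and a 17-fold lower number from compound 2 to compound 4 (1.23 log units; beyond the scatter) showing that neither a ring alone, as in compound 3, nor a nitrogen alone, as in compound 2, is enough to reach this level. Nothing measured here explains these differences.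

Still open, as far as these compounds go, is whether the hydroxyl and the arrangement of the two defined stereocentres matter for the ring of compound 4. A plain pyrrolidine ring, a hydroxylated piperidine ring or a methyl group on the ring nitrogen would each test a different part of this group.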